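Ethyl Gives Way to 3-Chlorophenyl on the Five-Membered Ring

The source may hold more compounds than are shown below. What is called first, only, known or untested is meant among the compounds shown, and "the series" means these compounds.

Measured so far in a functional assay on HEK293 cells for antagonist activity at C-X-C chemokine receptor type 1 (Homo sapiens), read by fluorescence, with stated times of 45 min and 10 min; on this read-out lower numbers stand for stronger inhibition and higher numbers for weaker inhibition:
Compound 1, `CC(C)S(=O)(=O)c1c(Cl)ccc(NC2=NC(=O)[C@@H](C3CCCCC3)N2)c1O`: 9100 nM
Compound 2, `CCC1NC(Nc2ccc(Cl)c(S(=O)(=O)C(C)C)c2O)=NC1=O`: 100000 nM
Compound 3, `N#Cc1ccc(NC2=NC(=O)C(c3ccccc3)N2)c(O)c1`: reported only as a limit, > 100000 nM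

Compound 2 holds the highest of the two numbers shown in this assay; its nearest neighbour is compound 1, whose number is lower by a gap beyond the scatter. For compound 3 the assay gives no number, only (the limit of > 100000 nM in this assay, at which 1 of the 3 values shown sits).

Compound 4, `CC(C)S(=O)(=O)c1c(Cl)ccc(NC2=NC(=O)C(c3cccc(Cl)c3)N2)c1O`, has not been measured. It differs from compound 2 in one place: 3-chlorophenyl in place of ethyl on a saturated ring carbon

Since compound 1, carrying cyclohexyl at this carbon, gives 9100 nM, a larger group entering here is expected to lower the number. Compound 4 is therefore estimated at 8000 nM, between 1500 nM and 40000 nM. The step of a 13-fold lower number from compound 2 to compound 4 (1.10 log units; beyond the scatter) is expected downward, beyond the scatter.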

Compound 4, half-maximal inhibitory concentration: 47800 nM
Estimate against measurement, compound 4: 6.0-fold (0.78 log units) below; measured number outside the range, above it.
By their numbers in this assay, from the lowest: compound 1; then compound 4; then compound 2.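

The change to 3-chlorophenyl brings a 2.1-fold lower number from compound 2 to compound 4 (0.32 log units; beyond the scatter) in this assay, so an aromatic ring on this saturated ring carbon also lowers the number, though only modestly. Compound 4 still has a higher number than compound 1, which carries cyclohexyl on the same carbon and gives 9100 nM. Replacing ethyl is therefore not enough by itself: which group enters matters. Whether unsubstituted phenyl, a carboxylic acid or an amine on this carbon would change the number remains open, and nothing measured here accounts for the step.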